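The source may hold more compounds than are shown below. What is called first, only, known or untested is meant among the compounds shown, and "the series" means these compounds.

Within the data shown here, compound 1 `CC1=C(/C=C/C(=O)/C=C/c2ccc(C)cc2)C(C)(C)CCC1` is one of two compounds measured in a functional assay on IMR-32 cells (Homo sapiens) for cytotoxicity, read by sulforhodamine B assay, with a stated time of 48 h; on this read-out lower numbers stand for stronger inhibition and higher numbers for weaker inhibition; in this assay compound 1 gives 19200 nM, the highest of the two numbers. Among the measured compounds shown here, compound 2 `CC1=C(/C=C/C(=O)/C=C/c2ccc([N+](=O)[O-])cc2)C(C)(C)CCC1` gives 3200 nM in this assay, and the single measured step, a 6.0-fold lower number from compound 1 to compound 2 (0.78 log units; beyond the scatter), comes from a nitro in place of methyl on an aromatic carbon. Compound 3 `CC1=C(/C=C/C(=O)/C=C/c2ccccc2C)C(C)(C)CCC1` has not yet been measured. It differs from compound 1 by 2-methylphenyl in place of 4-methylphenyl on a double-bonded chain carbon bound to a double-bonded chain carbon; the two have the same atoms, joined differently. For the measured compounds named here, no measured step moves a methyl from one aromatic carbon to another, so the step from compound 1 to compound 2 bears on the present change only loosely, and no step beyond the scatter is expected in this assay. For compound 3 the expected step is a 1.0-fold lower number from compound 1 to compound 3 (0.00 log units; within the scatter). Compound 3 is therefore estimated at 19000 nM in this assay, with a range from 7500 nM to 48000 nM.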

Compound 3, half-maximal inhibitory concentration: 63200 nM
Estimate against measurement, compound 3: 3.3-fold (0.52 log units) below, outside the stated range (above it).
By their numbers in this assay, from the lowest: compound 2; then compound 1; then compound 3.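

In this assay, the position of the methyl on the aromatic ring matters even though no atom is gained or lost: 2-methylphenyl in place of 4-methylphenyl gives a 3.3-fold higher number from compound 1 to compound 3 (0.52 log units; beyond the scatter). Among these compounds, the only earlier step, a 6.0-fold lower number from compound 1 to compound 2 (0.78 log units; beyond the scatter), exchanged one group for another and lowered the number, whereas this change keeps the same atoms, joins them differently and raises it. So the aryl group on the double-bonded chain carbon is sensitive to rearrangement alone, although no available measurement accounts for the rise.

The compounds shown leave open whether the nitro group of compound 2 would respond to the same move as the methyl does. They also do not show how an amine, a methoxy group or a chlorine would behave in the place of that methyl.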